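Thiazole for Thiophene on an Aromatic Carbon

The source may hold more compounds than are shown below. What is called first, only, known or untested is meant among the compounds shown, and "the series" means these compounds.

Compound 1, `c1c[nH]c(-c2ccccc2OCC2=NCCN2)c1`, gives 99% in a functional assay with Alpha-1A adrenergic receptor (Homo sapiens) as the target, read by calcium flux; a higher number here means a larger maximal response, a lower number a smaller maximal response.
Compound 2, `c1ccc(-c2ccsc2)c(OCC2=NCCN2)c1`, gives 98% in this assay.

By the bare number compound 2 is the lower of the two in this assay, but compound 1 lies within the scatter of it, so the two are not told apart. Compound 3, `c1ccc(-c2nccs2)c(OCC2=NCCN2)c1`, has not been measured yet. Its change from compound 2 is 1,3-thiazol-2-yl in place of thiophen-3-yl on an aromatic carbon. Within the data shown here, only one measured step offers any bearing: a number 1 percentage points lower from compound 1 to compound 2 (within the scatter), which likewise exchanged one five-membered aromatic ring for another on an aromatic carbon and moved the maximal response by nothing beyond the scatter. On that single precedent, another exchange of one five-membered aromatic ring for another is expected to leave the maximal response in this assay close to where compound 2 stands, with a number 3 percentage points lower from compound 2 to compound 3 (within the scatter) as the estimated step. For compound 3 the expected value in this assay is therefore 95%, with a range from 80% to 105%.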

Compound 3, largest response reached (reported as maximum), in percent of the reference or control that the assay uses: 102%
Compound 3: the middle estimate sits 7 percentage points below what was measured, within the range that was stated.
By their numbers in this assay, from the lowest: compounds 2, 1 and 3 (each within the scatter of the next).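

The step to 1,3-thiazol-2-yl in this assay is a number 4 percentage points higher from compound 2 to compound 3 (within the scatter) and shows that a five-membered aromatic ring with 2 hetero atoms can stand on this aromatic carbon, ortho to a group of 7 heavy atoms, without the maximal response being told apart from that of the ring with 1 hetero atom. The comparison with the 1H-pyrrol-2-yl group gives a number 3 percentage points higher from compound 1 to compound 3 (within the scatter) so three different five-membered aromatic rings now sit at this place with no step beyond the scatter. Nothing available bears on why the maximal response stays the same across these rings.

From the compounds shown here alone, whether an amine, a carboxylic acid or a longer chain on this carbon would keep the maximal response stays open. So does how these three compounds compare in any read-out other than the largest response reached.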